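The source may report more compounds than this note shows. Statements on the series, on what has been measured and on what is new or still open speak of the compounds shown alone.

Of the compounds shown here, three built on a shared core have been measured in an assay on nucleic acid for binding affinity to Salmon testes DNA (Salmonidae), tested at 10 uM; a lower number here means that the compound stabilises the target less, a higher number that the compound stabilises the target more against heat. Compound 1 `CN(C)CCCNC(=O)c1cc(NC(=O)c2cc(NC(=O)c3cc(NC(=N)N)cn3C)cn2C)cn1C` gives 5 degrees C. Compound 2 `COc1cccc(C(=N)Nc2cc(C(=O)Nc3cc(C(=O)Nc4cc(C(=O)NCCCN(C)C)n(C)c4)n(C)c3)n(C)c2)c1` gives 11 degrees C in this assay, and compound 3 `CN(C)CCCNC(=O)c1cc(NC(=O)c2cc(NC(=O)c3cc(NC(=N)c4ccccc4)cn3C)cn2C)cn1C` gives 11 degrees C. Compound 3 thus stands level with compound 2 at the digits shown, and the two together hold the highest numbers of the three, while compound 1 sits well apart, as the step of a number 6.0 degrees C higher from compound 1 to compound 3 (beyond the scatter) shows.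

Compound 4 `CN(C)CCCNC(=O)c1cc(NC(=O)c2cc(NC(=O)c3cc(NC(=N)c4cnc5ccccc5c4)cn3C)cn2C)cn1C` differs from compound 3 in one place: quinolin-3-yl in place of phenyl on a carbon with a double bond to nitrogen. Among the compounds with values here, two measured steps bear on this change. The first, a number 6.0 degrees C higher from compound 1 to compound 3 (beyond the scatter), shows that an aromatic group on the carbon with a double bond to nitrogen raises the shift by a large amount compared with amino. The second, no change at the digits printed from compound 2 to compound 3 (within the scatter), shows that altering what sits on that aromatic ring left the number unchanged within the scatter. The move from phenyl to quinolin-3-yl keeps an aromatic group in that place and only extends it, so the expected step of a number 1.0 degrees C higher from compound 3 to compound 4 (within the scatter) is small, likely none beyond the scatter, with a slight lean upward. Compound 4 is therefore estimated at 12 degrees C, with a range from 9 degrees C to 15 degrees C.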

Compound 4, shift of the target's melting temperature: > 17 degrees C
Compound 4 was reported as a limit (the forecaster's own chance of this, stated with the estimate: 0%); middle value at least 5.0 degrees C from the limit.
By their numbers in this assay, from the lowest: compound 1; then compounds 2 and 3 (each within the scatter of the next). At a limit, above all of these: compound 4.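

For compound 4, the reading in this assay is a limit and not a number: the limit of > 17 degrees C in this assay, at which 1 of the 4 values shown sits. Compound 2 and compound 3 had left open whether the choice of aromatic group on this carbon with a double bond to nitrogen matters, as 3-methoxyphenyl and phenyl lie within the scatter of each other, but quinolin-3-yl in place of phenyl gives a number at least 6.0 degrees C higher from compound 3 to compound 4 (beyond the scatter) and quinolin-3-yl in place of 3-methoxyphenyl gives a number at least 6.0 degrees C higher from compound 2 to compound 4 (beyond the scatter), so this position still responds once an aromatic group is present. Measured against the amino group of compound 1, quinolin-3-yl gives a number at least 12 degrees C higher from compound 1 to compound 4 (beyond the scatter), which shows that the gain seen with phenyl is not the most this position can give.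

Quinolin-3-yl brings both a second ring and a ring nitrogen, and the compounds shown do not tell these two apart: an all-carbon naphthalen-2-yl group, or a pyridin-3-yl group with the nitrogen in a single ring, would separate them. Going by these compounds, how far compound 4 lies past its limit also stays open, and with it the full size of these steps.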